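Adding a second chloro to a fused bicyclic core

The compounds below may be only part of what the source reports. "The series", "measured", "known", "first", "only" and "open" are said of these compounds alone.

Measured compounds in a functional assay on OVCAR-4 cells (Homo sapiens) for cytotoxicity, read by sulforhodamine B assay, with a stated time of 48 h; on this read-out higher numbers stand for weaker inhibition of growth and lower numbers for stronger inhibition of growth:
- compound 1, `ClCc1cccc(Cn2cnc3ncnc(Cl)c32)c1`, gives 4160 nM
- compound 2, `ClCc1cccc(Cn2cnc3c(Cl)ncnc32)c1`, gives 2340 nM
- compound 3, `ClCc1cccc(Cn2cnc3c(Cl)nc(Cl)nc32)c1`, gives 5490 nM

Compounds 1 and 2 are built from the same atoms joined differently; the difference between the two cores is not broken down here. Their values in this assay lie close together, within the usual scatter, so no order between them can be read from the numbers. Compound 3 carries one extra group compared with compound 2: chloro in place of hydrogen on an aromatic carbon. This change made a step of a 2.3-fold higher number from compound 2 to compound 3 (0.37 log units; beyond the scatter), a modest weakening of growth inhibition.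

Compound 4, `ClCc1cccc(Cn2cnc3nc(Cl)nc(Cl)c32)c1`, has not yet been measured. It differs from compound 1 by the same kind of change: chloro in place of hydrogen on an aromatic carbon. The place description of this change matches that of the step from compound 2 to compound 3 word for word, though it is made on a differently joined core, so it is the same change carried onto another core.

Among the compounds with values here, with only one measured example of this change, the expectation rests on that single step. Compound 4 is expected to show a step of a 2.3-fold higher number from compound 1 to compound 4 (0.36 log units; beyond the scatter), because the step of a 2.3-fold higher number from compound 2 to compound 3 (0.37 log units; beyond the scatter) was a modest weakening and nothing in the measured data points the other way. Compound 4 is therefore estimated at 9500 nM, with a range from 4000 nM to 22000 nM reflecting the uncertainty of a single precedent on a different core.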

Compound 4, concentration for 50% growth inhibition: 1580 nM
Compound 4: the middle estimate sits 6.0-fold (0.78 log units) above what was measured, and the stated range ends above it.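

In this assay, putting chloro in place of hydrogen on an aromatic carbon, between two ring nitrogen atoms, gave a 2.6-fold lower number from compound 1 to compound 4 (0.42 log units; beyond the scatter), which means stronger inhibition of growth rather than the weakening seen on the other core. The step measured on one core therefore did not predict even the direction of the step on the other, and the gap between the two is larger than repeated measurements would explain: the same change on two cores in this assay, a 2.3-fold higher number (0.37 log units; beyond the scatter) from compound 2 to compound 3 and a 2.6-fold lower number (0.42 log units; beyond the scatter) from compound 1 to compound 4, 6.2-fold (0.79 log units) apart, beyond the scatter of two such steps. This shows that, for these two pairs, the outcome of adding this chloro depends on how the core is joined, but it does not show why, and two pairs are too few to give a rule for any further core in the series.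

From the compounds shown here alone, it remains open whether another group on the same aromatic carbon, such as an amine or a methoxy group, would also pull the two cores in opposite directions or would shift both the same way. Going by these compounds, it is equally open whether the split between the cores would persist if the chloromethyl group on the benzene ring gave way to a longer chain or a carboxylic acid.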